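Moving from a methyl to a methoxy group on compound 3

The compounds below may be only part of what the source reports. "The series", "measured", "known", "first", "only" and "open" are said of these compounds alone.

Of the compounds shown here, three sharing one core have been tested in an ADME assay on cells (Hepatocyte, Homo sapiens) for pharmacokinetics, read by LC-MS, with a stated time of 90 min, tested at 1 uM; on this read-out lower numbers stand for slow clearance and higher numbers for fast clearance. Compound 1, `COc1ccc(Nc2c(NCCCCCC(=O)NO)c(=O)c2=O)cc1`, gives < 4.7 uL/min, which is a limit of the measurement rather than a number. Compound 2, `CC(CCCCC(=O)NO)Nc1c(Nc2ccccc2)c(=O)c1=O`, gives < 5 uL/min, again a limit. Compound 3, `Cc1ccc(Nc2c(NC(C)CCCCC(=O)NO)c(=O)c2=O)cc1`, gives < 6.5 uL/min, also a limit. Because all three values are limits, as shown by the limit of < 4.7 uL/min in this assay, at which 1 of the 3 values shown sits, the limit of < 5 uL/min in this assay, at which 1 of the 3 values shown sits, and (the limit of < 6.5 uL/min in this assay, at which 1 of the 3 values shown sits), no ordering among them can be read, and the one measured step, a step that the two limits leave unreadable from compound 2 to compound 3, has no readable size.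

Compound 4, `COc1ccc(Nc2c(NC(C)CCCCC(=O)NO)c(=O)c2=O)cc1`, differs from compound 3 in one place: methoxy in place of methyl on an aromatic carbon. Among the compounds with values here, no measured step of this kind exists among the three compounds, so the data offer no direction for the change. Compound 1 carries the same methoxy-bearing ring as compound 4, and its value is a limit, which suggests that the methoxy group does not by itself push the read-out into the measurable range. The expected step from compound 3 to compound 4 is therefore a step that the limit leaves unreadable from compound 3 to compound 4, no larger than the usual scatter. Compound 4 is expected to give about 3.5 uL/min in this assay, within a range from 1.5 uL/min to 8 uL/min, most likely reported again as a limit.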

Compound 4, intrinsic clearance in a liver preparation (reported as CLH), per the amount of preparation that the assay uses: 7.1 uL/min
The estimate for compound 4 lay 2.0-fold (0.31 log units) below the measured number; measured number inside the range.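

In this assay, within the data shown here, compound 4 is the first compound here to give a number rather than a limit, so the change from 4-methylphenyl to 4-methoxyphenyl can now be given a lower bound, an at least 1.0-fold higher number from compound 3 to compound 4 (0.03 log units; that floor lies within the scatter). Compound 3 itself stands only as a limit: the limit of < 6.5 uL/min in this assay, at which 1 of the 4 values shown sits. The two other comparisons give bounds of the same kind, with methoxy in place of hydrogen on the ring giving an at least 1.4-fold higher number from compound 2 to compound 4 (0.15 log units; that floor lies within the scatter), and methyl in place of hydrogen on the saturated chain carbon giving an at least 1.5-fold higher number from compound 1 to compound 4 (0.17 log units; that floor lies within the scatter), so each shows only a floor and none establishes a real rise in clearance.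

As far as these compounds go, the true size of all three steps stays open, since a number for compound 1, compound 2 or compound 3 would be needed to fix them, and the earlier step between compound 2 and compound 3 still cannot be read. Also open, from the compounds shown here alone, is how this position on the ring would respond to a different group, such as an amine or a carboxylic acid, in place of the methoxy of compound 4.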